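Cyano for ethoxycarbonyl: working notes on four compounds

The source may hold more compounds than are shown below. What is called first, only, known or untested is meant among the compounds shown, and "the series" means these compounds.

Measured in a functional assay on HT-29 cells (Homo sapiens) for inhibition, read by MTT assay; a lower number here means a stronger inhibitor, a higher number a weaker inhibitor:
compound 1 `N#Cc1c(N)sc(C(=O)Nc2ccc(Cl)cc2)c1-c1ccccc1` — 650 nM
compound 2 `CCOC(=O)c1c(N)sc(C(=O)Nc2ccc(Cl)cc2)c1-c1ccccc1` — 190 nM
compound 3 `CCOC(=O)c1c(NC(=O)CC#N)sc(C(=O)Nc2ccccc2)c1-c1ccccc1` — 630 nM

Compound 3 and compound 1 fall within the scatter of each other; compound 2 stands beyond the scatter from both. The difference between the cores of compound 2 and compound 3 is not broken down here. From compound 2 to compound 1 the change cyano in place of ethoxycarbonyl on an aromatic carbon gave a 3.4-fold higher number from compound 2 to compound 1 (0.53 log units; beyond the scatter). Compound 4 `N#CCC(=O)Nc1sc(C(=O)Nc2ccccc2)c(-c2ccccc2)c1C#N` is not yet measured; it carries the same kind of change from compound 3, (cyano in place of ethoxycarbonyl on an aromatic carbon), not the same: here the changed carbon is next to the ring atom that bears a ((cyanomethyl)carbonyl)amino group and two ring bonds from the ring atom that bears a phenylcarbamoyl group, where in compound 2 the corresponding atoms bear an amino group and a large group. A similar step is expected, a 3.3-fold higher number from compound 3 to compound 4 (0.52 log units; beyond the scatter), resting on a 3.4-fold higher number from compound 2 to compound 1 (0.53 log units; beyond the scatter) and on the value of compound 3, 630 nM. Compound 4 is thus estimated at 2100 nM, expected between 800 nM and 6000 nM.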

Compound 4, half-maximal inhibitory concentration: 6590 nM
For compound 4 the middle estimate is 3.1-fold (0.50 log units) below the measured one, outside the stated range (above it).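

In this assay cyano in place of ethoxycarbonyl gives a higher number on both cores, with a 10-fold higher number from compound 3 to compound 4 (1.02 log units; beyond the scatter), but the size of the step does not carry over: the same change on two cores in this assay, a 3.4-fold higher number (0.53 log units; beyond the scatter) from compound 2 to compound 1 and a 10-fold higher number (1.02 log units; beyond the scatter) from compound 3 to compound 4, 3.1-fold (0.49 log units) apart, beyond the scatter of two such steps

The direction is shared by these two pairs, so the earlier step gave the direction on the core of compound 3 but not the size. The two cores differ in more than one place, and these four compounds do not show which difference goes with the larger step.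

Open, on these data alone, is the size of the same change on a core pairing the amino group with the phenylcarbamoyl group. Also open, as far as these compounds go, is how a carboxylic acid or a methyl ester in place of ethoxycarbonyl would compare on either core.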